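The source may hold more compounds than are shown below. What is called first, only, known or untested is meant among the compounds shown, and "the series" means these compounds.

Three compounds share one core and differ only in the group on the amine nitrogen in a ring. Compound 1 `CCCCNc1nc(N)nc2c1CCN(Cc1ccccc1)C2` carries a benzyl group there, and in an assay on HEK293 cells for agonist activity at Toll-like receptor 8 (Homo sapiens), read by a luciferase reporter, with a stated time of 6 h (a higher number here means that more compound is needed for the effect, a lower number that less compound is needed), compound 1 gives 0.4 uM. Compound 3 `CCCCNc1nc(N)nc2c1CCN(S(C)(=O)=O)C2` carries a methylsulfonyl group instead, and in this assay compound 3 gives 0.8 uM; this change gave a 2.0-fold higher number from compound 1 to compound 3 (0.30 log units; within the scatter). Compound 2 `CCCCNc1nc(N)nc2c1CN(C(=O)c1ccccc1)CC2` carries a benzoyl group, and in this assay compound 2 gives 1.4 uM, the highest of the three numbers: the gap to compound 3 lies within the scatter, while the gap to compound 1 lies beyond it.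

Compound 4 `CCCCNc1nc(N)nc2c1CN(C(=O)C1CCC1)CC2` differs from compound 2 in one place: cyclobutyl in place of phenyl on a carbonyl carbon. Among the compounds with values here, none of the measured steps alters the group on a carbonyl carbon; the only measured step swaps the whole group on the ring nitrogen and stayed within the scatter. Within the data shown here, with no directly comparable step to lean on, the expected step of no change at the digits printed from compound 2 to compound 4 (within the scatter) is none beyond the scatter. Compound 4 is therefore estimated at 1.4 uM, with a range from 0.5 uM to 4 uM.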

Compound 4, minimum effective concentration: 0.4 uM
Compound 4: the middle estimate sits 3.5-fold (0.54 log units) above what was measured, and the stated range ends above it.
By their numbers in this assay, from the lowest: compounds 1, 4, 3 and 2 (each within the scatter of the next, the first and the last beyond it).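

The group on the carbonyl carbon does matter: in this assay, cyclobutyl in place of phenyl gave a 3.5-fold lower number from compound 2 to compound 4 (0.54 log units; beyond the scatter), the only step shown so far that lies beyond the scatter. An aromatic ring on this carbonyl carbon is therefore not required for the effect, as a four-membered non-aromatic carbon ring with fewer heavy atoms gives a lower number than phenyl. No measurement here explains why this swap lowers the number.

Within the data shown here, with only two groups compared on this carbonyl carbon, ring size cannot be separated from the loss of the aromatic ring, and a cyclopropyl ring, a cyclohexyl ring or an open butyl chain there would help to do so. Going by these compounds, how an amine or a carboxylic acid on the cyclobutyl ring would change the number also remains open.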